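The source may hold more compounds than are shown below. What is called first, only, known or untested is meant among the compounds shown, and "the series" means these compounds.

Measured in a functional assay on NPC-TW01 cells (Homo sapiens) for inhibition, read by MTT assay, with a stated time of 72 h; a higher number here means a weaker inhibitor of growth, a lower number a stronger inhibitor of growth:
- compound 1 `Nc1c(C=O)c(-c2ccc(Cl)cc2)nn1-c1cccc(Cl)c1`: > 100000 nM (a limit)
- compound 2 `Cc1ccc(-c2nn(-c3ccc(Br)cc3)c(N)c2C=O)cc1`: 28200 nM

Compound 2 stands alone as the holder of a true number, 28200 nM. Compound 1 gives > 100000 nM, which is a limit of the assay and not a number.

Compound 3 `Nc1c(C=O)c(-c2ccc(Cl)cc2)nn1-c1ccc(Br)cc1` departs from compound 2 in one place: chloro in place of methyl on an aromatic carbon. This is chloro in place of methyl on an aromatic carbon, para to a large group, or 4-methylphenyl to 4-chlorophenyl. Going by the values given here, no measured pair isolates this change, so in this assay only a small step is expected, perhaps slightly towards weaker growth inhibition. Compound 1, which also carries 4-chlorophenyl, reads > 100000 nM, a limit, so the expected range reaches further on the weaker side. The expected step is a 1.2-fold higher number from compound 2 to compound 3 (0.07 log units; within the scatter). For compound 3 the estimate is 33000 nM, with an expected range of 13000 nM to 85000 nM.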

Compound 3, concentration for 50% growth inhibition: 59700 nM
Compound 3: the middle estimate sits 1.8-fold (0.26 log units) below what was measured; low and high end bracket the measured number.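

In this assay, going by these compounds alone, the change from 4-methylphenyl to 4-chlorophenyl gives a first true reading for this position, para to a large group (a 2.1-fold higher number from compound 2 to compound 3 (0.33 log units; beyond the scatter)), so the swap of methyl for chloro is modest but does register beyond the scatter. With 4-chlorophenyl held in place, a second change, 4-bromophenyl in place of 3-chlorophenyl on the aromatic nitrogen, can be read only as a floor (an at least 1.6-fold lower number from compound 1 to compound 3 (0.22 log units; that floor lies within the scatter)). Compound 1 reads > 100000 nM, which is a limit of the assay and not a number: the limit of > 100000 nM in this assay, at which 1 of the 3 values shown sits.

The compounds shown leave open how a methoxy, a fluoro or a trifluoromethyl group would read at this same position. They also leave open how far the change on the aromatic nitrogen truly reaches, and they cannot say why chloro and methyl differ here.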